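A Pyridin-4-yl Group on the Ring Nitrogen

The source may hold more compounds than are shown below. What is called first, only, known or untested is meant among the compounds shown, and "the series" means these compounds.

Among the compounds with values here, compound 1 `O=C1NC(=O)C2(CSC3=C2C(=O)c2ncccc2C3=O)N1` stands at the weaker end of the two numbers so far: in a functional assay on SF-268 cells (Homo sapiens) for antiproliferative activity, read by MTT assay, with a stated time of 96 h (a higher number here means a weaker inhibitor, a lower number a stronger inhibitor), compound 1 gives 3100 nM. Compound 2 `CCCCCc1ccc(N2C(=O)NC3(CSC4=C3C(=O)c3ncccc3C4=O)C2=O)cc1` gives 520 nM in this assay, a gap beyond the scatter. Compound 3 `O=C1C2=C(C(=O)c3ncccc31)C1(CS2)NC(=O)N(c2ccncc2)C1=O` differs from compound 1 by pyridin-4-yl in place of hydrogen on an amide-type nitrogen in a ring. Within the data shown here, no pair of measured compounds differs in just one place, so the comparison rests on compound 1 and compound 2 alone. The step of a 2.6-fold lower number from compound 1 to compound 3 (0.41 log units; beyond the scatter) is expected to be a moderate move toward a lower number. Compound 3 is estimated at 1200 nM, within a range from 400 nM to 3500 nM.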

Compound 3, half-maximal inhibitory concentration: 1100 nM
Compound 3: the middle estimate sits 1.1-fold (0.04 log units) above what was measured; the measured number falls inside the stated range.
By their numbers in this assay, from the lowest: compound 2; then compound 3; then compound 1.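

Measured in this assay the swap of hydrogen for pyridin-4-yl on this amide-type nitrogen in a ring gives a 2.8-fold lower number from compound 1 to compound 3 (0.45 log units; beyond the scatter) as the first single change read at this position. So this nitrogen can carry an aromatic ring containing a ring nitrogen, and the number still falls modestly, beyond the scatter. Nothing available here accounts for that fall. Still open, as far as these compounds go, is whether a plain phenyl ring or a pyridin-3-yl ring on this nitrogen would give a different number. A short chain such as methyl poses the same question.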